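Swapping a Cyclic Amine for a Propyl Chain

A few compounds are considered here, and "the series" means these few. Any claim that something is new, unique, unknown or untested is made for them only; others in the source may bear on it.

Compound 1 `O=C1Nc2ccccc2/C1=N/NC(=S)N1CCCC1`, compound 2 `O=C1/C(=N\NC(=S)Nc2ccccc2)c2ccccc2N1c1ccccc1` and compound 3 `COc1ccccc1NC(=S)N/N=C1\C(=O)Nc2ccccc21` have each been examined in an ADME assay on RD cells (Homo sapiens) for cytotoxicity; on this read-out higher numbers stand for lower toxicity in this test and lower numbers for higher toxicity in this test. Compound 1 gives > 25000 nM, which is a limit of the assay and not a number. Compound 2 likewise gives > 25000 nM, a limit. Compound 3 gives > 25000 nM, again a limit. The shared picture is the limit of > 25000 nM in this assay, at which 3 of the 3 values shown sit, so compound 1 stands where every other tested compound stands. Compound 4 `CCCNC(=S)N/N=C1\C(=O)Nc2ccccc21` differs from compound 1 by propylamino in place of pyrrolidin-1-yl on a thiocarbonyl carbon. Among the compounds with values here, no step between measured compounds is known, and the limits give no direction. The step in this assay is therefore expected to stay within the scatter, as a step that the limit leaves unreadable from compound 1 to compound 4. Compound 4 is expected to give 30000 nM, between 15000 nM and 60000 nM.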

Compound 4, half-maximal cytotoxic concentration: > 25000 nM
Compound 4 was reported as a limit; the forecaster's own chance of this, stated with the estimate: 70%; the middle value lies beyond the limit too.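

In this assay, compound 1 and compound 4 are both reported only as limits, so no step can be read between them. The compounds shown leave open whether propylamino in place of pyrrolidin-1-yl alters this read-out at all.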